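The source may report more compounds than this note shows. Statements on the series, on what has been measured and on what is new or still open speak of the compounds shown alone.

Compound 1 `O=c1nc(-c2ccccc2)c2cc(-c3cnc4ccccc4c3)ccc2[nH]1`: > 16000 nM
Compound 2 `O=c1nc(-c2ccccc2)c2cc(-c3ccccc3)ccc2[nH]1`: > 50000 nM

In an ADME assay on L6 cells (Rattus norvegicus) for cytotoxicity, read by fluorescence and resazurin assay, with a stated time of 72 h (on this read-out lower numbers stand for an effect already at smaller amounts and higher numbers for an effect only at larger amounts of compound), compound 2 stands only at a limit, > 50000 nM, and so has no number of its own. Compound 1 also stands only at a limit, > 16000 nM. Going by the values given here, no measured step links the two compounds, so the data offer no direct guide to the size of a change at this position.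

Compound 3 `O=c1nc(-c2ccccc2)c2cc(-c3cn[nH]c3)ccc2[nH]1` carries 1H-pyrazol-4-yl in place of phenyl on an aromatic carbon, (1H-pyrazol-4-yl in place of phenyl on an aromatic carbon). This expectation starts from the limit of compound 2, > 50000 nM. In this assay only a small move toward lower numbers is expected, hardly beyond the usual scatter, and the estimated change is an at least 1.2-fold lower number from compound 2 to compound 3 (0.09 log units; that floor lies within the scatter). For compound 3 the expected value is 40000 nM, with an estimated range from 12000 nM to 100000 nM.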

Compound 3, half-maximal effective concentration: > 50000 nM
Compound 3: only a limit was reported; the forecaster's own chance of this, stated with the estimate: 60%; at least 1.2-fold (0.09 log units) between middle value and limit.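

Compound 2 and compound 3 both stand only at a limit, so no step can be read from one to the other: the limit of > 50000 nM in this assay, at which 2 of the 3 values shown sit.

The compounds shown leave open how far 1H-pyrazol-4-yl in place of phenyl moves the read-out, and what number of its own each compound would have.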